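Silicon-bearing group in place of methoxyphenyl on compound 2

The compounds below may be only part of what the source reports. "The series", "measured", "known", "first", "only" and "open" are said of these compounds alone.

Measured compounds:
Compound 1 `O=C1O/C(=C\Cn2cc(-c3ccc(Br)cc3)nn2)C(OCc2ccccc2)=C1OCc1ccccc1` — in a functional assay on MCF7 cells (Homo sapiens) for antiproliferative activity, read by MTT assay, with a stated time of 72 h (on this read-out lower numbers stand for stronger inhibition and higher numbers for weaker inhibition), compound 1 gives > 100000 nM, which is a limit of the assay.
Compound 2 `COc1ccccc1-c1cn(C[C@H](O)[C@H]2OC(=O)C(OCc3ccccc3)=C2OCc2ccccc2)nn1` — in this assay compound 2 gives > 100000 nM, likewise a limit of the assay.
Compound 3 `O=C1O/C(=C\Cn2cc(-c3cccc(O)c3)nn2)C(OCc2ccccc2)=C1OCc1ccccc1` — in this assay compound 3 gives 27800 nM.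

Compound 2 thus stands at the limit of > 100000 nM in this assay, at which 2 of the 3 values shown sit; no number is known for it, only that it lies beyond the range the assay reports.

Compound 4 `C[Si](C)(C)c1cn(C[C@H](O)[C@H]2OC(=O)C(OCc3ccccc3)=C2OCc2ccccc2)nn1` differs from compound 2 by a group of 4 heavy atoms (3 carbon, 1 silicon; no ring) in place of a group of 8 heavy atoms (7 carbon, 1 oxygen; one six-membered aromatic ring of carbon only), on an aromatic carbon.

Within the data shown here, only one measured step exists, and it does not sit on the core of compound 2: an at least 3.5-fold lower number from compound 1 to compound 3 (0.55 log units; beyond the scatter). That step shows the group on the five-membered aromatic ring with 3 nitrogen can move the number out of the limit when one six-membered aromatic ring of carbon only replaces another. No measured pair removes that ring altogether, so nothing shown speaks directly to the change from compound 2 to compound 4.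

Given that compound 2 is itself a limit, compound 4 is expected to remain near the limit, with an at least 1.1-fold lower number from compound 2 to compound 4 (0.04 log units; that floor lies within the scatter) as the expected step. Compound 4 is therefore estimated at 90000 nM, within 30000 nM to 300000 nM, and it may well return only a limit again.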

Compound 4, half-maximal inhibitory concentration: 12100 nM
Compound 4: middle estimate off by 7.4-fold (0.87 log units), on the high side; the whole stated range lies above it.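

In this assay, replacing the 2-methoxyphenyl with the silicon-bearing group gives an at least 8.2-fold lower number from compound 2 to compound 4 (0.91 log units; beyond the scatter), so on this core a six-membered aromatic ring at this aromatic carbon of the five-membered aromatic ring with 3 nitrogen is not required for a measured value. The earlier step, an at least 3.5-fold lower number from compound 1 to compound 3 (0.55 log units; beyond the scatter), exchanged one six-membered aromatic ring for another on a different core, and so could not show what happens when the ring leaves altogether. The size of the new step is only a floor, since compound 2 gives > 100000 nM, which is a limit of the assay and not a number: the limit of > 100000 nM in this assay, at which 2 of the 4 values shown sit.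

Whether the silicon atom itself matters stays open, since the compounds shown include no tert-butyl group at this position, and that all-carbon group would separate the silicon atom from the overall change in group. Going by these compounds, it is also open whether the silicon-bearing group gives a similar step on the core of compound 1, and whether a smaller or more different group at this position, such as a methyl group or an amine, would also give a measured value.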